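Hexylphenyl series: ester in place of acrylamide

The source may report more compounds than this note shows. Statements on the series, on what has been measured and on what is new or still open speak of the compounds shown alone.

Two compounds carry a measurement in an in vitro assay on BL21-DE3 cells for displacement of a labelled ligand from thyroid hormone receptor beta (Homo sapiens), read by fluorescence polarization; a higher number here means a weaker inhibitor, a lower number a stronger inhibitor. Compound 1 `CCCCCCc1ccc(C(=O)CCN2CCC(C(=O)OC)CC2)cc1` gives 3900 nM in this assay. Compound 2 `C/C=C/C(=O)Nc1ccc(CCCCCC)cc1` gives > 100000 nM in this assay, and that figure is a limit of the assay rather than a number. Compound 2 therefore stands at the weak end of what has been seen, with only a limit to its name; the limit of > 100000 nM in this assay, at which 1 of the 2 values shown sits, is where one of the two values shown sits. Among the measured compounds shown here, no measured pair differs in a single place, so no measured step is available for this series.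

Compound 3 `C#CC(=O)Oc1ccc(CCCCCC)cc1` is not yet measured. It differs from compound 2 by (ethynylcarbonyl)oxy in place of ((prop-1-en-1-yl)carbonyl)amino on an aromatic carbon, para to a hexyl group, with the hexyl chain kept. With compound 2 at a limit, the step from compound 2 to compound 3 in this assay cannot be fixed from the data; it is expected to be of modest size in either direction, most likely within the scatter, as a number no higher from compound 2 to compound 3 (the limit leaves the size open). Compound 3 is expected to give about 100000 nM in this assay, within 20000 nM to 500000 nM, with a real chance that again only a limit is reported.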

Compound 3, half-maximal inhibitory concentration: 6200 nM
For compound 3 the middle estimate is 16-fold (1.21 log units) above the measured one; the whole stated range lies above it.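

In this assay, (ethynylcarbonyl)oxy in place of ((prop-1-en-1-yl)carbonyl)amino on an aromatic carbon, para to a hexyl group, gives an at least 16-fold lower number from compound 2 to compound 3 (1.20 log units; beyond the scatter). This position is therefore not indifferent to the group it carries, even with the hexyl chain kept: with (ethynylcarbonyl)oxy there, compound 3 gives a readable value of 6200 nM. Compound 2 is held at a limit of the assay and not at a number, so the step has a smallest size but no fixed size: the limit of > 100000 nM in this assay, at which 1 of the 3 values shown sits.

The change replaces the amide nitrogen with an ester oxygen and the propenyl end with an ethynyl end in one move, and the compounds shown do not separate these two parts, so the step cannot be assigned to either. Also open, as far as these compounds go, is how this position reads with an ethynyl amide, which would hold the nitrogen and change only the end of the group, and how the series responds to a butyl chain in place of the hexyl chain.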